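The compounds below may be only part of what the source reports. "The series", "measured", "known", "first", "only" and "open" are said of these compounds alone.

Compound 1 `COc1cc(C)nc2n/c(=N/C(=O)c3c(-c4ccc(Cl)cc4Cl)noc3C)sn12` is the strongest of three measured compounds in a functional assay on the whole organism for inhibition, with Chenopodium ficifolium as the target, with a stated time of 72 h, tested at 100 mg/L (a higher number here means more inhibition of growth at the concentration tested, a lower number less inhibition of growth), where compound 1 gives 80.4%. Compound 2 `COc1cc(Cl)nc(NC(=S)NC(=O)c2c(-c3ccc(Cl)cc3Cl)noc2C)n1` gives 53.2%, and compound 3 `Cc1cc(Cl)nc(NC(=S)NC(=O)c2c(-c3ccc(Cl)cc3Cl)noc2C)n1` gives 48.3%. Compound 2 and compound 3 share a core that differs from the core of compound 1; that difference is not broken down here. Between them stands one change, (methoxy in place of methyl on an aromatic carbon), which made a step of a number 4.9 percentage points higher from compound 3 to compound 2 (within the scatter).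

Compound 4 `COc1cc(OC)n2s/c(=N\C(=O)c3c(-c4ccc(Cl)cc4Cl)noc3C)nc2n1` arises from compound 1 by the same kind of change, (methoxy in place of methyl on an aromatic carbon). The surroundings differ: in compound 1 the ring is part of a fused or bridged system of two rings, meta and para to a fused ring and meta to a methoxy group, whereas in compound 3 the carbon is meta to a chloro group and meta to a large group. Since the step from compound 3 to compound 2 was a number 4.9 percentage points higher from compound 3 to compound 2 (within the scatter), a similar step of a number 1.6 percentage points higher from compound 1 to compound 4 (within the scatter) is expected, so compound 4 is estimated at 82%, between 68% and 92%.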

Compound 4, percent growth inhibition at one concentration: 82.7%
Compound 4: middle estimate off by 0.7 percentage points, on the low side; the range from low to high includes it.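

In this assay, methoxy in place of methyl on an aromatic carbon gave a step of a number 2.3 percentage points higher from compound 1 to compound 4 (within the scatter). Set beside the same change on the other core, the two steps agree: the same change on two cores in this assay, a number 4.9 percentage points higher (within the scatter) from compound 3 to compound 2 and a number 2.3 percentage points higher (within the scatter) from compound 1 to compound 4, 2.6 percentage points apart, within the scatter of two such steps. This shows that the change reads alike on both cores, but it does not show that the change has a real effect on either, as neither step can be told from the scatter, and two cores cannot speak for the whole series.

The compounds shown leave open what a clearly different group would do at this place on the ring. An amine or a longer chain such as butoxy might separate from methyl and methoxy, or might not.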